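This account rests on a few compounds, and the source may have more. Where it says the series, first, only, none or still open, it means among the compounds named here.

Three compounds sharing one core have numbers in a functional assay on SK-BR-3 cells (Homo sapiens) for antiproliferative activity; a lower number here means a stronger inhibitor, a higher number a weaker inhibitor. Compound 1 (`COc1ccc(C(=O)Nc2cc3ccc(OC4CCN(C)CC4)c(C)c3oc2=O)cc1CC=C(C)C`) gives 1410 nM, compound 2 (`Cc1c(OC2CCN(C)CC2)ccc2cc(NC(=O)c3ccc(O)c(CCC(C)C)c3)c(=O)oc12`) gives 600 nM, and compound 3 (`C=CCc1cc(C(=O)Nc2cc3ccc(OC4CCN(C)CC4)c(C)c3oc2=O)ccc1OC(C)=O`) gives 2260 nM. Compound 3 thus stands within the scatter of compound 1, while compound 2 has a lower number than compound 3, a gap beyond the scatter.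

Compound 4 (`COc1cccc(-c2cc(C(=O)Nc3cc4ccc(OC5CCN(C)CC5)c(C)c4oc3=O)ccc2OC(C)=O)c1`) carries 3-methoxyphenyl in place of allyl on an aromatic carbon, ortho to an acetoxy group, and is otherwise identical to compound 3: 3-methoxyphenyl in place of allyl on an aromatic carbon. For the measured compounds named here, no pair of measured compounds differs in one place only, so the data offer no direct guide to this swap, and all three measured compounds carry open chains at this position. No step beyond the scatter is expected in this assay, in either direction, though this expectation is loose. The expected step is a 1.3-fold lower number from compound 3 to compound 4 (0.10 log units; within the scatter). For compound 4 the estimated value is 1800 nM, with an expected range of 600 nM to 5500 nM.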

Compound 4, half-maximal inhibitory concentration: 920 nM
For compound 4 the middle estimate is 2.0-fold (0.29 log units) above the measured one; low and high end bracket the measured number.
By their numbers in this assay, from the lowest: compounds 2, 4, 1 and 3 (each within the scatter of the next, the first and the last beyond it).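

In this assay, the step to the aromatic ring gives a 2.5-fold lower number from compound 3 to compound 4 (0.39 log units; beyond the scatter), a modest change but one that lies beyond the scatter. For the compounds shown here, the three earlier compounds carried only open chains at this position, so this is the first sign that the aromatic carbon ortho to the acetoxy group accepts a six-membered aromatic ring and a much larger group, 8 heavy atoms against 3, with no loss in this read-out. The data shown offer nothing that accounts for the lower number.

Going by these compounds, what a plain phenyl or a pyridyl ring would give on this carbon remains open, so the ring itself cannot be separated from its methoxy group. Also open, on these data alone, is whether the step would hold with a hydroxy group in place of the acetoxy group.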